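Fluoro for chloro on the bicyclic arm of compound 1

The compounds below may be only part of what the source reports. "The series", "measured", "known", "first", "only" and "open" are said of these compounds alone.

Compound 1, `COc1ccc2c(C3CCc4ccc(Cl)cc43)ncnc2c1OC`: 4 nM
Compound 2, `COc1ccc2c(C(C)c3cccc(Cl)c3)ncnc2c1OC`: 22 nM

In an assay on isolated protein for inhibition of dual specificity calcium/calmodulin-dependent 3',5'-cyclic nucleotide phosphodiesterase 1B (Homo sapiens) (a lower number here means a stronger inhibitor, a higher number a weaker inhibitor), compound 1 gives 4 nM, the lowest of the two numbers measured. Its nearest neighbour is compound 2, which in this assay gives 22 nM, a gap that lies beyond the scatter of repeated measurements. The step followed here leads from compound 1 to compound 3, `COc1ccc2c(C3CCc4ccc(F)cc43)ncnc2c1OC`, not yet measured in this assay. The change is fluoro in place of chloro on an aromatic carbon. Exchanges of one halogen for another at a single aromatic carbon are usually modest in this kind of assay, and nothing among the measured compounds speaks for a large shift. Compound 3 is therefore expected to land near compound 1, with the step of a 2.3-fold higher number from compound 1 to compound 3 (0.35 log units; beyond the scatter) anticipated as a slight rise, at the edge of the scatter or just beyond it. The estimate for compound 3 in this assay is 9 nM, within a range from 3 nM to 30 nM.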

Compound 3, half-maximal inhibitory concentration: 38 nM
Beside the measured number, compound 3's estimate is 4.2-fold (0.63 log units) below it, outside the stated range (above it).
By their numbers in this assay, from the lowest: compound 1; then compounds 2 and 3 (each within the scatter of the next).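

In this assay, going by these compounds alone, the exchange at this aromatic carbon gives a 9.5-fold higher number from compound 1 to compound 3 (0.98 log units; beyond the scatter), so the position distinguishes between the two halogens even though only a single heavy atom changes. Within the data shown here, until this result, chloro was the only group seen at this place, and nothing showed how far the number depended on it. With these two compounds, chloro is the better of the two halogens here, while nothing measured bears on why the step has this size.

The compounds shown leave open how bromo, methyl or nitrile at this carbon would read in this assay, and where a bare hydrogen would fall relative to compound 1 and compound 3. They also leave open whether the same exchange on the arm of compound 2 would give a step of similar size.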